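Adding an Acetyl Group to an Aromatic Amine

A few compounds are considered here, and "the series" means these few. Any claim that something is new, unique, unknown or untested is made for them only; others in the source may bear on it.

Compound 1 `COc1cc(/C=C/C(=O)c2cccc(N)c2)ccc1O` is the parent of this small set. In a functional assay on HUVEC cells (Homo sapiens) for inhibition, tested at 5 ug/mL (on this read-out higher numbers stand for a stronger effect at the one concentration tested and lower numbers for a weaker effect), compound 1 gives 50%. Compound 2 `CCOC(=O)C(=O)Nc1cccc(C(=O)/C=C/c2ccc(O)c(OC)c2)c1` gives 45% in this assay, and compound 3 `COc1cc(/C=C/C(=O)c2cccc(NC(=O)c3c(Cl)cccc3Cl)c2)ccc1O` gives 88%. Compound 1 therefore sits between the other two: its neighbour compound 2 lies close by, as the step of a number 5 percentage points lower from compound 1 to compound 2 (within the scatter) shows, while compound 3 lies far above it, as the step of a number 38 percentage points higher from compound 1 to compound 3 (beyond the scatter) shows.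

The change to compound 4 `COc1cc(/C=C/C(=O)c2cccc(NC(C)=O)c2)ccc1O` is acetyl in place of hydrogen on a nitrogen on an aromatic ring. This is the same kind of change as in the two measured steps, since in both of them a hydrogen on a nitrogen on an aromatic ring was exchanged for a group attached through a carbonyl. The small ethoxycarbonylcarbonyl group left the number essentially unchanged in the step of a number 5 percentage points lower from compound 1 to compound 2 (within the scatter), whereas the larger (2,6-dichlorophenyl)carbonyl group raised it strongly in the step of a number 38 percentage points higher from compound 1 to compound 3 (beyond the scatter). Acetyl is small, like the first of these, so no step beyond the scatter is expected in this assay, and compound 4 is expected to give about 55%, between 35% and 75%, which means an estimated step of a number 5 percentage points higher from compound 1 to compound 4 (within the scatter).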

Compound 4, a percentage reported as inhibition, at one concentration (the size of the read-out at that concentration, not a potency): 15%
Compound 4: middle estimate off by 40 percentage points, on the high side; measured number outside the range, below it.
By their numbers in this assay, from the lowest: compound 4; then compounds 2 and 1 (each within the scatter of the next); then compound 3.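

Placing a carbonyl-linked group on this nitrogen has no single direction of effect: acetyl in place of hydrogen gives a number 35 percentage points lower from compound 1 to compound 4 (beyond the scatter), whereas the earlier replacements left the number within the scatter or raised it. With the amide kept, the group on the far side of the carbonyl has a large influence on the number, as methyl in place of 2,6-dichlorophenyl gives a number 73 percentage points lower from compound 3 to compound 4 (beyond the scatter) and methyl in place of ethoxycarbonyl gives a number 30 percentage points lower from compound 2 to compound 4 (beyond the scatter), so a small group here is not automatically a harmless one. Nothing available explains why the acetamido compound gives so much lower a number than its neighbours.

On these data alone, it remains open whether the low number belongs to methyl alone on this carbonyl, or whether ethyl, a longer chain such as butyl, or an unsubstituted phenyl would fall near compound 4 or nearer compound 3. As far as these compounds go, it also remains open whether the carbonyl is needed at all, which a plain methyl or benzyl group placed directly on the nitrogen could help to show.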